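From Ethyl to Isopropyl in a Cell Assay

A few compounds are considered here, and "the series" means these few. Any claim that something is new, unique, unknown or untested is made for them only; others in the source may bear on it.

In a functional assay on HCT-116 cells (Homo sapiens) for inhibition (a higher number here means a weaker inhibitor, a lower number a stronger inhibitor), compound 1 (`CCNC(=O)c1noc(-c2cc(C(C)C)c(O)cc2O)c1-c1cc(C(=O)OCC)no1`) is recorded as "not determined" (no result reported) and so offers no comparison. Going by the values given here, that leaves compound 2 (`CCNC(=O)c1noc(-c2cc(C(C)C)c(O)cc2O)c1-c1ccn(CC)n1`) at 25 nM as the only number available, with nothing to rank it against. Compound 3 (`CCNC(=O)c1noc(-c2cc(C(C)C)c(O)cc2O)c1-c1ccn(C(C)C)n1`) departs from compound 2 in a single place: methyl in place of hydrogen on a saturated chain carbon bound to an aromatic nitrogen and a saturated chain carbon. Put simply, the ethyl group becomes isopropyl, turning 1-ethyl-1H-pyrazol-3-yl into 1-isopropyl-1H-pyrazol-3-yl. Among the compounds with values here, no measured step shows how such a change plays out here, so the expectation rests only on the value of compound 2 and the small size of the change. The expected step is a 1.2-fold higher number from compound 2 to compound 3 (0.08 log units; within the scatter) and should be slightly weakening at most, without going beyond the scatter of repeated measurements. For compound 3 the estimated value is 30 nM, with 12 nM to 80 nM as the expected range.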

Compound 3, half-maximal inhibitory concentration: 19 nM
Beside the measured number, compound 3's estimate is 1.6-fold (0.20 log units) above it; the measured number falls inside the stated range.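

Going by these compounds alone, this is the first measured step at this position. Adding a methyl on a saturated chain carbon bound to an aromatic nitrogen and a saturated chain carbon, which turns ethyl into isopropyl, gives a 1.3-fold lower number from compound 2 to compound 3 (0.12 log units; within the scatter) in this assay. The position therefore takes this one extra carbon with no difference that stands out from repeat-measurement noise, and the two compounds count as equal in this assay, but nothing at hand gives a reason for that.

Only ethyl and isopropyl are shown at this position, so a single step cannot reveal how far the tolerance extends. From the compounds shown here alone, how a longer chain such as butyl, a cyclopropyl ring, or a chain ending in an amine or a carboxylic acid would behave here remains open.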